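Clearance notes: the step from compound 3 to compound 4

This account rests on a few compounds, and the source may have more. Where it says the series, first, only, none or still open, it means among the compounds named here.

- compound 1 `Cc1nc(-c2nc3ccccc3[nH]2)c(N2CCN(C(=O)Cn3cnc4cccnc43)[C@H](C)C2)s1`: 23 mL.min-1.g-1
- compound 2 `C[C@@H]1CN(c2sc(CN(C)C)nc2-c2nc3ccccc3[nH]2)CCN1C(=O)Cn1cnc2cccnc21`: 44 mL.min-1.g-1
- compound 3 `CCOc1ncc(-c2nc(C(F)(F)F)sc2N2CCN(C(=O)Cn3ccc4cnccc43)[C@H](C)C2)cn1`: 656 mL.min-1.g-1

In a toxicity assay on microsomes from liver (Homo sapiens) for metabolic stability, read by LC-MS, using NADPH, tested at 1 uM (a lower number here means slower removal, a higher number faster removal of the compound), compound 3 stands highest of the three at 656 mL.min-1.g-1, beyond the scatter from both others. Compound 4 `CCOc1ncc(-c2nc(C(F)(F)F)sc2N2CCN(C(=O)Cn3ccc(C(F)(F)F)n3)[C@H](C)C2)cn1` carries 3-(trifluoromethyl)-1H-pyrazol-1-yl on a saturated chain carbon bound to a carbonyl carbon: a group of 9 heavy atoms (4 carbon, 2 nitrogen, 3 fluorine; one five-membered aromatic ring with 2 hetero atoms) in place of a group of 9 heavy atoms (7 carbon, 2 nitrogen; one five-membered aromatic ring with 1 hetero atom, one six-membered aromatic ring with 1 hetero atom), on a saturated chain carbon bound to a carbonyl carbon. Going by the values given here, the one measured step, a 1.9-fold higher number from compound 1 to compound 2 (0.28 log units; within the scatter), concerns another place and gives no direct size for this change. With compound 3 at the top of the series at 656 mL.min-1.g-1, a modest drop is expected, with wide uncertainty. The expected step is a 2.2-fold lower number from compound 3 to compound 4 (0.34 log units; beyond the scatter). The estimate for compound 4 is 300 mL.min-1.g-1, with an expected range of 90 mL.min-1.g-1 to 900 mL.min-1.g-1.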

Compound 4, intrinsic clearance in microsomes: 20 mL.min-1.g-1
For compound 4 the middle estimate is 15-fold (1.18 log units) above the measured one; the whole stated range lies above it.
By their numbers in this assay, from the lowest: compounds 4, 1 and 2 (each within the scatter of the next, the first and the last beyond it); then compound 3.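

The group on the saturated chain carbon bound to a carbonyl carbon has a large bearing on clearance: in this assay, 3-(trifluoromethyl)-1H-pyrazol-1-yl in place of the earlier two-ring group gives a 33-fold lower number from compound 3 to compound 4 (1.52 log units; beyond the scatter). The only earlier step, a 1.9-fold higher number from compound 1 to compound 2 (0.28 log units; within the scatter), concerned another place and lay within the scatter, so this position is the first shown to move the number beyond it. No measurement here accounts for the size of this step.

On these data alone, it remains open whether the trifluoromethyl or the loss of the six-membered aromatic ring carries the step, which a plain 1H-pyrazol-1-yl or a methyl on the same ring could separate. As far as these compounds go, whether the same exchange acts alike on the core of compound 1 also remains open.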